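A few compounds are considered here, and "the series" means these few. Any claim that something is new, unique, unknown or untested is made for them only; others in the source may bear on it.

In a functional assay on K562 cells (Homo sapiens) for antiproliferative activity, read by MTT assay, with a stated time of 48 h (a lower number here means a stronger inhibitor, a higher number a weaker inhibitor), the measured compounds stand as follows:

Compound 1, `CCN(CC)CCn1c(N)c(-c2nc3ccccc3[nH]2)c2nc(C#N)c(C#N)nc21`, gives 2490 nM.
Compound 2, `CN1CCN(CCn2c(N)c(-c3nc4ccccc4[nH]3)c3nc(C#N)c(C#N)nc32)CC1`, gives 6550 nM.
Compound 3, `CCN(CC)CCCn1c(N)c(-c2nc3ccccc3[nH]2)c2nc(C#N)c(C#N)nc21`, gives 1800 nM.

Compound 4, `CN1CCN(CCCn2c(N)c(-c3nc4ccccc4[nH]3)c3nc(C#N)c(C#N)nc32)CC1`, has not yet been measured in this assay. Compound 1 and compound 2 differ by 4-methylpiperazin-1-yl in place of diethylamino on a saturated chain carbon, two bonds along the chain from an aromatic nitrogen, and that change made a step of a 2.6-fold higher number from compound 1 to compound 2 (0.42 log units; beyond the scatter). Compound 3 and compound 4 differ by 4-methylpiperazin-1-yl in place of diethylamino on a saturated chain carbon, three bonds along the chain from an aromatic nitrogen. These are the same kind of change rather than the same change: in compound 1 the exchanged group sits on a saturated chain carbon, two bonds along the chain from an aromatic nitrogen, whereas in compound 3 it sits on a saturated chain carbon, three bonds along the chain from an aromatic nitrogen. The two cores differ by (diethylamino)methyl in place of diethylamino on a saturated chain carbon, two bonds along the chain from an aromatic nitrogen, which gave a 1.4-fold lower number from compound 1 to compound 3 (0.14 log units; within the scatter), a step within the scatter, so there is little ground for expecting the swap of diethylamino for 4-methylpiperazin-1-yl to behave differently on the longer chain. The step expected here is a 2.6-fold higher number from compound 3 to compound 4 (0.42 log units; beyond the scatter), because the same kind of change gave a 2.6-fold higher number from compound 1 to compound 2 (0.42 log units; beyond the scatter). Compound 4 is therefore estimated at 4700 nM, most likely between 2000 nM and 11000 nM.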

Compound 4, half-maximal inhibitory concentration: 1260 nM
The estimate for compound 4 lay 3.7-fold (0.57 log units) above the measured number; the whole stated range lies above it.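

In this assay, the swap of diethylamino for 4-methylpiperazin-1-yl did not carry over from the shorter chain to the longer one, and the two results differ by more than the scatter of the measurements: the same change on two cores in this assay, a 2.6-fold higher number (0.42 log units; beyond the scatter) from compound 1 to compound 2 and a 1.4-fold lower number (0.15 log units; within the scatter) from compound 3 to compound 4, 3.8-fold (0.57 log units) apart, beyond the scatter of two such steps. On the longer chain the swap gives a 1.4-fold lower number from compound 3 to compound 4 (0.15 log units; within the scatter), so it makes no clear difference there. Among the piperazine compounds, the longer chain gives a 5.2-fold lower number from compound 2 to compound 4 (0.72 log units; beyond the scatter), whereas the step with both the amine and the chain changed, a 2.0-fold lower number from compound 1 to compound 4 (0.30 log units; within the scatter), stays within the scatter. This shows that, in these two pairs, the result of the swap depends on the chain that carries it, but two pairs cannot show why, or predict the swap on another core.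

The compounds shown leave open how a longer chain, such as a four-carbon one, would behave with either amine. They also leave open whether other ring amines, such as morpholine or piperidine, would depend on chain length in the same way.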